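This account rests on a few compounds, and the source may have more. Where it says the series, first, only, none or still open, it means among the compounds named here.

In a physicochemical assay for solubility (on this read-out higher numbers stand for higher solubility and lower numbers for lower solubility), compound 3 (`O=C(Nc1nc(-c2cccc(C(F)(F)F)c2F)cs1)c1cnc(N2CCC(C(=O)O)CC2)c(C(F)(F)F)c1`) gives < 10 ug/mL as a limit of the assay and not a number. Compound 1 (`O=C(Nc1nc(-c2cccc(C(F)(F)F)c2F)cs1)c1ccc(N2CCC(C(=O)O)CC2)nc1`) gives < 10 ug/mL as a limit too. Compound 2 (`O=C(Nc1nc(-c2cccc(C(F)(F)F)c2F)cs1)c1cnc(N2CCC(C(=O)O)CC2)c(Br)c1`) gives < 10 ug/mL as another limit. Compound 3 therefore stands with the others at the limit of < 10 ug/mL in this assay, at which 3 of the 3 values shown sit, and has no exact number to start from.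

Compound 4 (`N#Cc1cc(C(=O)Nc2nc(-c3cccc(C(F)(F)F)c3F)cs2)cnc1N1CCC(C(=O)O)CC1`) differs from compound 3 by one change (cyano in place of trifluoromethyl on an aromatic carbon), which is cyano in place of trifluoromethyl on an aromatic carbon, ortho to a 4-carboxypiperidin-1-yl group. The measured swaps on that same carbon are a step that the two limits leave unreadable from compound 1 to compound 2 and a step that the two limits leave unreadable from compound 1 to compound 3 and also a step that the two limits leave unreadable from compound 2 to compound 3 so none offers a size to carry over. Among the compounds with values here, with hydrogen, bromo and trifluoromethyl there, no compound rises clear of the limit in this assay and no step beyond the usual scatter is expected in either direction. The estimated change is a step that the limit leaves unreadable from compound 3 to compound 4 and a further limit is the likeliest report. For compound 4 the expected value is 6 ug/mL with an estimated range of 2 ug/mL to 20 ug/mL in this measurement.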

Compound 4, solubility: < 10 ug/mL
Compound 4: no number, only a limit; the forecaster's own chance of this, stated with the estimate: 80%; the middle value lies beyond the limit too.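

Within the data shown here, no step from compound 1, compound 2 or compound 3 to compound 4 can be read in this assay, because all four compounds give a limit of the assay and not a number: the limit of < 10 ug/mL in this assay, at which 4 of the 4 values shown sit.

The compounds shown leave open the true value of each compound in this assay and whether hydrogen, bromo, trifluoromethyl or cyano on that aromatic carbon makes any difference.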